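A few compounds are considered here, and "the series" means these few. Any claim that something is new, unique, unknown or untested is made for them only; others in the source may bear on it.

Measured compounds:
- compound 1 `O=C(Nc1cccc(-c2oc3cc(-c4ccc(F)cc4)ccc3c(=O)c2O)c1)c1ccc(F)cc1F` with 11200 nM in a functional assay on MDA-MB-231 cells (Homo sapiens) for antiproliferative activity, read by CCK-8 assay, with a stated time of 72 h; a lower number here means a stronger inhibitor, a higher number a weaker inhibitor
- compound 2 `Cc1cc(C(=O)Nc2cccc(-c3oc4cc(-c5ccc(F)cc5)ccc4c(=O)c3O)c2)ccc1F` with 7440 nM in this assay

Among the measured compounds shown here, compound 2 and compound 1 are the only two measured members, and the single step between them, a 1.5-fold lower number from compound 1 to compound 2 (0.18 log units; within the scatter), lies within the scatter, so the two numbers stand together and neither can be called the stronger one. Compound 3 `COc1ccc(C(=O)Nc2cccc(-c3oc4cc(-c5ccc(F)cc5)ccc4c(=O)c3O)c2)c(F)c1` has not yet been measured. It differs from compound 2 in one place: 2-fluoro-4-methoxyphenyl in place of 4-fluoro-3-methylphenyl on a carbonyl carbon. For the measured compounds named here, the only measured step that bears on this change is the swap on the same carbonyl carbon from compound 1 to compound 2, which stayed within the scatter. On that basis, a shift beyond the scatter in this assay is not expected in either direction; the step of a 1.1-fold higher number from compound 2 to compound 3 (0.06 log units; within the scatter) is the expected size. For compound 3 the estimate is 8500 nM, with a range from 3500 nM to 20000 nM.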

Compound 3, half-maximal inhibitory concentration: 17600 nM
The estimate for compound 3 lay 2.1-fold (0.32 log units) below the measured number; the range from low to high includes it.
By their numbers in this assay, from the lowest: compounds 2, 1 and 3 (each within the scatter of the next, the first and the last beyond it).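

In this assay, among the compounds shown here, the swap to 2-fluoro-4-methoxyphenyl in place of 4-fluoro-3-methylphenyl on this carbonyl carbon is the first change here to pass the scatter, though only modestly (a 2.4-fold higher number from compound 2 to compound 3 (0.37 log units; beyond the scatter)). Methoxy in place of fluoro on an aromatic carbon stays within the scatter (a 1.6-fold higher number from compound 1 to compound 3 (0.20 log units; within the scatter)), so changing the aromatic group at this place can move the number, but not every such change does so measurably. Nothing available here explains the size of either step.

The swap from compound 2 to compound 3 alters the ring in more than one way at once, so these compounds cannot show which part of it carries the step. They also leave open how the number would respond to an amine or a carboxylic acid on this ring.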